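This account rests on a few compounds, and the source may have more. Where it says the series, first, only, none or still open, it means among the compounds named here.

In a functional assay on SMMC-7721 cells (Homo sapiens) for inhibition, read by MTT assay, with a stated time of 48 h (on this read-out higher numbers stand for weaker inhibition and lower numbers for stronger inhibition), three compounds with the same core differ in the ring group on an amide-type nitrogen. Compound 1 (`Nc1n[nH]c2cccc(-c3cccc(NC(=O)Nc4ccc(F)c(F)c4)c3)c12`) gives 5880 nM and sits within the usual scatter of compound 2 (`Nc1n[nH]c2cccc(-c3cccc(NC(=O)Nc4cc(C(F)(F)F)cc(C(F)(F)F)c4)c3)c12`), which gives 3540 nM as its value. Compound 3 (`Nc1n[nH]c2cccc(-c3cccc(NC(=O)Nc4ccccc4F)c3)c12`) gives 2360 nM and lies lower than compound 1 by more than the scatter.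

Compound 4 (`COc1cccc(NC(=O)Nc2cccc(-c3cccc4[nH]nc(N)c34)c2)c1`) carries a new change at that place (3-methoxyphenyl in place of 3,4-difluorophenyl on an amide-type nitrogen), with 3-methoxyphenyl in place of 3,4-difluorophenyl on an amide-type nitrogen. Among the measured compounds shown here, no measured compound carries this group, so the evidence is indirect. The nearest guide is the swap at the same place that gave a 2.5-fold lower number from compound 1 to compound 3 (0.40 log units; beyond the scatter) and counts as modest. With compound 2 at 3540 nM as well, swaps here have so far moved the number little. In this assay the expected step is therefore small and downward, namely a 1.7-fold lower number from compound 1 to compound 4 (0.23 log units; within the scatter) and possibly nothing beyond the scatter. For compound 4 the estimate is 3500 nM with 1500 nM to 8000 nM as the expected range.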

Compound 4, half-maximal inhibitory concentration: 2860 nM
For compound 4 the middle estimate is 1.2-fold (0.09 log units) above the measured one; the range from low to high includes it.
By their numbers in this assay, from the lowest: compounds 3, 4, 2 and 1 (each within the scatter of the next, the first and the last beyond it).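

In this assay, the swap to 3-methoxyphenyl gives a 2.1-fold lower number from compound 1 to compound 4 (0.31 log units; beyond the scatter), a modest step, so 2-fluorophenyl is no longer the only group on this amide-type nitrogen shown to move the number past the scatter from the level of 3,4-difluorophenyl. Compound 4 is the first compound here with no fluorine on this ring, and the comparison with the 2-fluorophenyl group gives a 1.2-fold higher number from compound 3 to compound 4 (0.08 log units; within the scatter), so among these compounds fluorine on the ring is not needed to reach this level. Nothing available explains the step from 3,4-difluorophenyl to 3-methoxyphenyl.

As far as these compounds go, it remains open whether that step comes from adding the methoxy group or from losing the two fluorines, a question that a plain phenyl ring carrying neither would address. The compounds shown also say nothing about how this place responds to a ring bearing an amine or a carboxylic acid, or to a longer chain in place of the ring.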